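Swapping a Bromopyridine for a Fused Two-Ring Group

The source may hold more compounds than are shown below. What is called first, only, known or untested is meant among the compounds shown, and "the series" means these compounds.

Compound 2, `CC[C@H]1OC(=O)[C@H](C)C(=O)[C@H](C)[C@@H](O[C@@H]2O[C@H](C)C[C@H](N(C)C)[C@H]2O)[C@](C)(O)C[C@@H](C)C(=O)[C@H](C)[C@H]2N(C3CN(Cc4ccncc4Br)C3)C(=O)O[C@]12C`, carries a 3-bromopyridin-4-yl group on a saturated chain carbon bound to an amine nitrogen in a ring. In an ADME assay on microsomes from liver (Homo sapiens) for metabolic stability, tested at 1 uM (on this read-out higher numbers stand for higher hepatic extraction and lower numbers for lower hepatic extraction), compound 2 reaches only a limit of the measurement, > 0.8. Compound 1, `CC[C@H]1OC(=O)[C@H](C)C(=O)[C@H](C)[C@@H](O[C@@H]2O[C@H](C)C[C@H](N(C)C)[C@H]2O)[C@](C)(O)C[C@@H](C)C(=O)[C@H](C)[C@H]2N(C3CN(Cc4c(OC)cnc5ncccc45)C3)C(=O)O[C@]12C`, carries instead a group of 12 heavy atoms with 2 six-membered aromatic rings with 1 hetero atom each, and in this assay compound 1 gives 0.8. For the measured compounds named here, the one measured step, a number no lower from compound 1 to compound 2 (the limit leaves the size open), cannot be sized because of the limit of > 0.8 in this assay, at which 1 of the 2 values shown sits. Compound 3, `CC[C@H]1OC(=O)[C@H](C)C(=O)[C@H](C)[C@@H](O[C@@H]2O[C@H](C)C[C@H](N(C)C)[C@H]2O)[C@](C)(O)C[C@@H](C)C(=O)[C@H](C)[C@H]2N(C3CN(Cc4c(O)cnc5cccnc45)C3)C(=O)O[C@]12C`, differs from compound 2 in one place: a group of 11 heavy atoms (8 carbon, 2 nitrogen, 1 oxygen; 2 six-membered aromatic rings with 1 hetero atom each) in place of a group of 7 heavy atoms (5 carbon, 1 nitrogen, 1 bromine; one six-membered aromatic ring with 1 hetero atom), on a saturated chain carbon bound to an amine nitrogen in a ring. The group entering compound 3 resembles the group of compound 1, whose value of 0.8 therefore guides the expectation. The expected step is a number no higher from compound 2 to compound 3 (the limit leaves the size open), its size left open by the limit. Compound 3 is estimated at 0.8, between 0.65 and 0.9.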

Compound 3, hepatic extraction ratio: < 0.3
Compound 3: no number, only a limit (the forecaster's own chance of this, stated with the estimate: 30%); at least 0.50 between middle value and limit.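

At this place, on a saturated chain carbon bound to an amine nitrogen in a ring, the choice of group can shift the read-out strongly: in this assay there is a number at least 0.50 lower from compound 2 to compound 3 (beyond the scatter). Having two rings does not settle the value, for the groups of compound 1 and compound 3 each hold 2 six-membered aromatic rings with 1 hetero atom each, and still there is a number at least 0.50 lower from compound 1 to compound 3 (beyond the scatter). Going by these compounds, compound 3 gives < 0.3, a limit and not a number, and the full size of both steps stays open: the limit of < 0.3 in this assay, at which 1 of the 3 values shown sits.

Compound 3 is the only compound shown with its two-ring group, so the part of that group that goes with the drop cannot be singled out. On these data alone, whether an amine or a carboxylic acid on the same two rings would give a similar read-out also remains open.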